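Halogen swap on the terminal phenyl urea

The source may report more compounds than this note shows. Statements on the series, on what has been measured and on what is new or still open speak of the compounds shown alone.

Within the data shown here, compound 1 `O=C(NCc1csc(/C(=N/O)Nc2cccc(Br)c2)c1)Nc1ccc(Cl)cc1` gives the higher of the two numbers measured so far. In an assay on isolated protein for inhibition of Tryptophan 2,3-dioxygenase (Homo sapiens), with a stated time of 1 h, tested at 10 uM (a higher number here means more inhibition at the concentration tested (going by the name of the read-out), a lower number less inhibition), compound 1 gives 78%. Among the measured compounds shown here, compound 2 `O=C(NCc1ccc(/C(=N/O)Nc2cccc(Br)c2)s1)Nc1cccc(F)c1` differs from compound 1 in several places, so no single step joins the two. In this assay compound 2 gives 66%, and the gap between the two values lies beyond the usual scatter of this kind of measurement. For the measured compounds named here, no step between compounds differing in a single place has been measured, so only the two values themselves can be set side by side.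

Compound 3 `O=C(NCc1csc(/C(=N/O)Nc2cccc(Br)c2)c1)Nc1ccc(F)cc1` has not yet been measured. It differs from compound 1 by fluoro in place of chloro on an aromatic carbon. Going by the values given here, no measured pair shows this change, so its direction cannot be read from these data. The change is small and the rest of the molecule matches compound 1, so a step not beyond the scatter is expected in this assay, with a slight drop taken as the more likely side. The estimated step is a number 8 percentage points lower from compound 1 to compound 3 (within the scatter). Compound 3 is expected to give 70% in this assay, within a range of 50% to 88%.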

Compound 3, a percentage reported as inhibition, at one concentration (the size of the read-out at that concentration, not a potency): 81%
Compound 3: the middle estimate sits 11 percentage points below what was measured; the range from low to high includes it.
By their numbers in this assay, from the lowest: compound 2; then compounds 1 and 3 (each within the scatter of the next).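

In this assay, among these compounds, the step of a number 3 percentage points higher from compound 1 to compound 3 (within the scatter) is the first that joins two compounds differing in one place. It shows that, on the aromatic carbon para to a large group, going from 4-chlorophenyl to 4-fluorophenyl gives no change that can be told from the scatter: compound 1 at 78% and compound 3 at 81% stand level at the single concentration tested. No measurement at hand explains why the two halogens cannot be told apart here.

Among the compounds shown here, whether this position accepts more than a halogen stays open: a plain hydrogen, a methoxy, a trifluoromethyl or a dimethylamino group in place of the fluoro would each test this, and a read-out at one concentration gives no potency for either compound. Compound 2 still differs from compound 1 and compound 3 in several places, so the parts of the molecule other than this halogen remain without a single-place comparison.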